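Aryl substituent changes and tissue distribution in the series

The source may hold more compounds than are shown below. What is called first, only, known or untested is meant among the compounds shown, and "the series" means these compounds.

Compound 3 `Cc1ccccc1[C@@]1(O)C[C@H](C(=O)Nc2ccc(-n3ccccc3=O)cn2)N(C(=O)Nc2ccc(Cl)cc2)C1` stands second highest of the three measured compounds in an in vivo ADME assay on the whole organism for pharmacokinetics, with Rattus norvegicus as the target, using cassette dosing (on this read-out lower numbers stand for narrower distribution and higher numbers for wider distribution into tissues), where compound 3 gives 0.468 L/kg. Its nearest neighbour is compound 2 `Cc1cccc([C@@]2(O)C[C@H](C(=O)Nc3ccc(-n4ccccc4=O)cn3)N(C(=O)Nc3ccc(Cl)cc3)C2)c1`, which in this assay gives 0.438 L/kg; the step of a 1.1-fold higher number from compound 2 to compound 3 (0.03 log units; within the scatter) lies within the scatter. Furthest off is compound 1 `Cc1ccc([C@@]2(O)C[C@H](C(=O)Nc3ccc(-n4ccccc4=O)cn3)N(C(=O)Nc3ccc(Cl)cc3)C2)cc1`, which in this assay gives 1.58 L/kg; the steps of a 3.6-fold lower number from compound 1 to compound 2 (0.56 log units; beyond the scatter) and a 3.4-fold lower number from compound 1 to compound 3 (0.53 log units; beyond the scatter) both exceed the scatter.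

Compound 4 `O=C(Nc1ccc(-n2ccccc2=O)cn1)[C@H]1C[C@](O)(c2ccccc2Cl)CN1C(=O)Nc1ccc(Cl)cc1` differs from compound 3 by chloro in place of methyl on an aromatic carbon. Among the measured compounds shown here, none of the measured steps exchanges methyl for chloro; all three change only where the methyl sits on the phenyl. The two steps that reach beyond the scatter both involve compound 1, while compound 2 and compound 3 lie within the scatter of each other. There is thus no measured ground for a step beyond the scatter in this assay, and the expected step of a 1.1-fold higher number from compound 3 to compound 4 (0.03 log units; within the scatter) is small. Compound 4 is estimated at 0.5 L/kg, with a range from 0.25 L/kg to 1 L/kg.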

Compound 4, volume of distribution at steady state: 0.923 L/kg
The estimate for compound 4 lay 1.8-fold (0.27 log units) below the measured number, within the range that was stated.
By their numbers in this assay, from the lowest: compounds 2, 3, 4 and 1 (each within the scatter of the next, the first and the last beyond it).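

Among the compounds shown here, the first change of the group itself on this aromatic carbon, rather than of where the methyl sits, gives a 2.0-fold higher number from compound 3 to compound 4 (0.29 log units; within the scatter) in this assay, so 2-chlorophenyl and 2-methylphenyl cannot be told apart on this read-out. Compound 4 still shows a 2.1-fold higher number from compound 2 to compound 4 (0.32 log units; beyond the scatter), yet a 1.7-fold lower number from compound 1 to compound 4 (0.23 log units; within the scatter) places it within the scatter of the 4-methylphenyl compound, so the earlier split into one higher compound and a close lower pair no longer describes the set cleanly. Nothing at hand gives a cause for these numbers.

As far as these compounds go, whether chloro depends on its place on the phenyl as methyl did remains open, with a 4-chlorophenyl group as the direct test. Also open, from the compounds shown here alone, is what an amine or a carboxylic acid on this aromatic carbon would give in this assay.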